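The source may hold more compounds than are shown below. What is called first, only, known or untested is meant among the compounds shown, and "the series" means these compounds.

For the measured compounds named here, in an assay on HEK293 cells for agonist activity at transient receptor potential cation channel subfamily M member 8 (Homo sapiens), read by fluorescence and calcium flux, with a stated time of 15 min (a lower number here means that less compound is needed, a higher number that more compound is needed for the effect), three compounds have numbers so far. Compound 1 `CCN(Cc1ccccc1)C(=O)COc1ccc(C)cc1` gives 1880 nM. Compound 2 `CCN(Cc1cccs1)C(=O)C[C@H](O)c1ccccc1` gives 52000 nM, and compound 3 `CCN(Cc1cccs1)C(=O)COc1ccc2c(c1)COC2` gives 61 nM. Among these three numbers compound 1 stands second highest: compound 2 lies above it and compound 3 below it, each by a gap beyond the usual scatter. Compound 4 `CCN(Cc1c[nH]nn1)C(=O)COc1ccc(C)cc1` has not been measured yet. It differs from compound 1 in a single place: 1H-1,2,3-triazol-4-yl in place of phenyl on a saturated chain carbon bound to an amide-type nitrogen. Going by the values given here, no pair of measured compounds shows a change of this kind, so the step can only be estimated. In this assay the expected step of a 3.2-fold higher number from compound 1 to compound 4 (0.50 log units; beyond the scatter) is a rise in the number beyond the scatter. Compound 4 is therefore expected to give about 6000 nM, within a range from 1500 nM to 30000 nM.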

Compound 4, half-maximal effective concentration: 31100 nM
Compound 4: the middle estimate sits 5.2-fold (0.71 log units) below what was measured; the whole stated range lies below it.
By their numbers in this assay, from the lowest: compound 3; then compound 1; then compounds 4 and 2 (each within the scatter of the next).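

In this assay, putting 1H-1,2,3-triazol-4-yl in place of phenyl on a saturated chain carbon bound to an amide-type nitrogen produces a 17-fold higher number from compound 1 to compound 4 (1.22 log units; beyond the scatter), the first single-place step available here. This position therefore does not treat these two aromatic rings alike: the phenyl form needs far less compound for the effect. No measurement shown gives the reason for this large step. Still open, as far as these compounds go, is how a pyridine ring would fare here, and whether a methyl group on a triazole nitrogen would change the number.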